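The compounds below may be only part of what the source reports. "The series", "measured", "known", "first", "only" and "open" are said of these compounds alone.

Compound 1 `COc1ccccc1CN1CCC=C(CCC(=O)NO)C1=O` gives > 10000 nM in a functional assay on MDA-MB-231 cells (Homo sapiens) for inhibition, read by sulforhodamine B assay (a higher number here means a weaker inhibitor of growth, a lower number a stronger inhibitor of growth), and this figure is a limit of the assay, not a number. Of the three compounds measured, only compound 1 stands there: the limit of > 10000 nM in this assay, at which 1 of the 3 values shown sits. Two relatives with the same hydroxamic acid chain do return numbers in this assay: compound 2 `COc1ccc(CN2CCC=C(CCC(=O)NO)C2=O)cc1` gives 3860 nM, and compound 3 `Cc1ccc(S(=O)(=O)Nc2ccc(CN3CCC=C(CCC(=O)NO)C3=O)cc2)cc1` gives 560 nM.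

The next compound, compound 4 `Cc1ccccc1CN1CCC=C(CCC(=O)NO)C1=O`, keeps the core of compound 1 and carries methyl in place of methoxy on an aromatic carbon, ortho to a large group (methyl in place of methoxy on an aromatic carbon). Among the measured compounds shown here, no measured pair shows this swap, so the expectation is a cautious one: no step beyond the scatter in this assay, and no firm direction. Compound 4 may well stop at the same limit rather than give a number. The estimated change is an at least 1.1-fold lower number from compound 1 to compound 4 (0.04 log units; that floor lies within the scatter). For compound 4 the estimated value is 9000 nM, with an expected range from 3000 nM to 25000 nM.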

Compound 4, concentration for 50% growth inhibition: 4920 nM
For compound 4 the middle estimate is 1.8-fold (0.26 log units) above the measured one; the measured number falls inside the stated range.
By their numbers in this assay, from the lowest: compound 3; then compounds 2 and 4 (each within the scatter of the next). At a limit, above all of these: compound 1.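

Among the compounds shown here, on an aromatic carbon, ortho to a large group, methyl in place of methoxy gives the first pair in this assay that differs in one place, and compound 4 returns a number, 4920 nM. Across this pair the change is an at least 2.0-fold lower number from compound 1 to compound 4 (0.30 log units; that floor lies within the scatter), which fixes only the smallest size the step can have, not its true size. Compound 1 remains at > 10000 nM, which is a limit of the assay and not a number, so the step can be read only as a floor: the limit of > 10000 nM in this assay, at which 1 of the 4 values shown sits.

Going by these compounds, it remains open whether a chlorine atom, a hydroxyl or an amine on this same aromatic carbon would give a lower number than methyl does. Also open, on these data alone, is whether methyl in place of methoxy would move the number of compound 2.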